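A few compounds are considered here, and "the series" means these few. Any claim that something is new, unique, unknown or untested is made for them only; others in the source may bear on it.

Of the compounds shown here, three have been tested in a functional assay on L1210 cells (Mus musculus) for antiproliferative activity; a higher number here means a more potent compound, by a factor of ten per unit of this negative logarithm, a lower number a less potent compound. Compound 1 `CCCCN(C)/N=N/c1n[nH]cc1C(=O)OCC` gives 3.16. Compound 2 `COC(=O)c1[nH]cnc1/N=N/N(C)C` gives 3.86 in this assay, the highest of the three numbers, and compound 3 `CCOC(=O)c1c[nH]nc1/N=N/N(C)C` gives 3.35. Compound 1 and compound 3 share a core and differ in one place: propyl in place of hydrogen on a saturated chain carbon bound to an amine nitrogen. That step, a number 0.19 log units lower from compound 3 to compound 1 (within the scatter), is small. The difference between the core of compound 2 and the core of compound 3 is not broken down here. Compound 4 `CCCCOC(=O)c1[nH]cnc1/N=N/N(C)C` has not yet been measured in this assay; it differs from compound 2 in one place: propyl in place of hydrogen on a saturated chain carbon bound to an oxygen next to a carbonyl group. Among the measured compounds shown here, this is the same kind of change as the one made from compound 3 to compound 1, a propyl group entering for a hydrogen, but the place differs: there the saturated chain carbon is bound to an amine nitrogen, here it is bound to an oxygen next to a carbonyl group. A similarly small step is expected here, a number 0.16 log units lower from compound 2 to compound 4 (within the scatter), resting on that single earlier pair. Compound 4 is therefore estimated at 3.7 in this assay, between 3.2 and 4.2.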

Compound 4, logarithm of the reciprocal of the active concentration, log(1/C): 3.53
Compound 4: middle estimate off by 0.17 log units, on the high side, and the stated range covers the measured number.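

Putting propyl in place of hydrogen on a saturated chain carbon bound to an oxygen next to a carbonyl group gives, in this assay, a number 0.33 log units lower from compound 2 to compound 4 (beyond the scatter), a modest step. Set beside the earlier step, the same kind of change behaves alike on the two cores as far as these numbers can tell: the same change on two cores in this assay, a number 0.19 log units lower (within the scatter) from compound 3 to compound 1 and a number 0.33 log units lower (beyond the scatter) from compound 2 to compound 4, 0.14 log units apart, within the scatter of two such steps

Among the compounds shown here, only two pairs stand behind this, and the chain sits at a different place in each; they show that the step carried over here without a clear shift, but not that it would keep this size on other cores, and they do not explain why it has this size.

As far as these compounds go, whether a chain longer than butyl would move the number further remains open. So does the effect on the number of an amine or a carboxylic acid at the end of the chain.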